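Ethoxy to isopropoxy on the shared core

The compounds below may be only part of what the source reports. "The series", "measured", "known", "first", "only" and "open" are said of these compounds alone.

Compounds measured so far:
compound 1, `CC1=NC(C)=C(C(=O)OCCCN2C(=O)c3ccccc3S2(=O)=O)C(c2cccc([N+](=O)[O-])c2)/C1=C(\O)OC(C)C` — in a functional assay (aorta) with Oryctolagus cuniculus as the target (a higher number here means a weaker inhibitor, a lower number a stronger inhibitor), compound 1 gives 1 nM
compound 2, `CO/C(O)=C1\C(C)=NC(C)=C(C(=O)OCCCN2C(=O)c3ccccc3S2(=O)=O)C1c1ccccc1[N+](=O)[O-]` — compound 2 gives 1.5 nM
compound 3, `CCO/C(O)=C1\C(C)=NC(C)=C(C(=O)OCCCN2C(=O)c3ccccc3S2(=O)=O)C1c1ccccc1[N+](=O)[O-]` — compound 3 gives 2.6 nM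

Compound 3 shows the highest number of the three, though its gap to compound 2 is within the scatter; only the gap to compound 1 lies beyond it. Compound 4, `CC1=NC(C)=C(C(=O)OCCCN2C(=O)c3ccccc3S2(=O)=O)C(c2ccccc2[N+](=O)[O-])/C1=C(\O)OC(C)C`, differs from compound 3 by methyl in place of hydrogen on a saturated chain carbon bound to an oxygen on an unsaturated carbon and a saturated chain carbon. Among the compounds with values here, the one measured step that bears on this is the same kind of addition one bond closer in, a 1.7-fold higher number from compound 2 to compound 3 (0.24 log units; within the scatter), which stayed within the scatter. Compound 4 is therefore expected to show no step beyond the scatter, a move of a 1.2-fold higher number from compound 3 to compound 4 (0.09 log units; within the scatter) in this assay. The estimate for compound 4 is 3.2 nM, with a range from 1.2 nM to 8 nM.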

Compound 4, half-maximal inhibitory concentration: 1.2 nM
Beside the measured number, compound 4's estimate is 2.7-fold (0.43 log units) above it; the range from low to high includes it.
By their numbers in this assay, from the lowest: compounds 1, 4, 2 and 3 (each within the scatter of the next, the first and the last beyond it).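

In this assay, within the data shown here, the change from ethoxy to isopropoxy gives a 2.2-fold lower number from compound 3 to compound 4 (0.34 log units; beyond the scatter), the first step beyond the scatter at this position, and it runs the opposite way to a 1.7-fold higher number from compound 2 to compound 3 (0.24 log units; within the scatter). Isopropyl in place of methyl on the same oxygen gives a 1.3-fold lower number from compound 2 to compound 4 (0.10 log units; within the scatter), and 2-nitrophenyl in place of 3-nitrophenyl gives a 1.2-fold higher number from compound 1 to compound 4 (0.08 log units; within the scatter), both within the scatter. No measurement available here accounts for this reversal. Going by these compounds, how a tert-butyl or cyclopentyl group on that oxygen would read remains open.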